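Isobutyl for tert-butyl at the ester oxygen

The compounds below may be only part of what the source reports. "The series", "measured", "known", "first", "only" and "open" are said of these compounds alone.

Measured so far:
compound 1 `CCCn1nc(Cc2ccccc2)c(C(=O)O)c1Cc1ccc(-c2ccccc2-c2nn[nH]n2)cc1` — 37.7%
compound 2 `CCCCn1nc(C)c(C(=O)O)c1Cc1ccc(-c2ccccc2S(=O)(=O)NC(=O)OC(C)(C)C)cc1` — 77.2%

In a functional assay on the whole organism for inhibition, with Rattus norvegicus as the target, at a dose of 1 mg/kg (a lower number here means less inhibition, a higher number more inhibition at the dose given (going by the name of the read-out)), compound 2 gives 77.2%, the higher of the two numbers shown. Compound 1 gives 37.7%, and the gap between the two compounds lies beyond the scatter. For the measured compounds named here, since compound 1 and compound 2 differ in more than one place, no single step between them is computed; the two values only show that compound 2 stands well above compound 1.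

Compound 3 `CCCCn1nc(C)c(C(=O)O)c1Cc1ccc(-c2ccccc2S(=O)(=O)NC(=O)OCC(C)C)cc1` differs from compound 2 in one place: isobutyl in place of tert-butyl on an oxygen next to a carbonyl group. The two have the same atoms, joined differently. Going by the values given here, no measured pair isolates a change of this kind, so there is no computed step to lean on. Because compound 2 gives 77.2%, compound 3 is expected to land close to that number; the step of a number 5.2 percentage points lower from compound 2 to compound 3 (within the scatter) is estimated to stay within the scatter, with no direction preferred. Compound 3 is therefore estimated at 72%, with a range from 50% to 90%.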

Compound 3, a percentage reported as inhibition, in the whole organism at one dose (the size of the read-out at that dose, not a potency): 76.3%
The estimate for compound 3 lay 4.3 percentage points below the measured number, and the stated range covers the measured number.
By their numbers in this assay, from the lowest: compound 1; then compounds 3 and 2 (each within the scatter of the next).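

In this assay, for the compounds shown here, the one step that can be read is a number 0.9 percentage points lower from compound 2 to compound 3 (within the scatter), for isobutyl in place of tert-butyl on an oxygen next to a carbonyl group. At this position, the two groups, with the same count of carbon atoms, cannot be told apart by this read-out. As the read-out comes from one dose and is not a potency, this says nothing about how the two compare at other doses.

Still open, going by these compounds, is whether a smaller group such as methyl, a longer chain such as n-hexyl, or a ring-bearing group such as benzyl on the same oxygen would also stay within the scatter of compound 3. The data shown offer no measured basis for explaining this result.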